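The compounds below may be only part of what the source reports. "The series", "measured", "known", "first", "only" and "open" are said of these compounds alone.

In a physicochemical assay for solubility (a higher number here means a more soluble compound, a lower number a less soluble compound), compound 1 `CS(=O)(=O)c1ccc(-n2nc(C(F)F)c(C#N)c2-c2ccccc2)cc1` has no number, and its entry reads "not determined" (no result reported). Compound 2 `C[C@@H]1CN(c2c(C#N)c(C(F)(F)F)nn2-c2ccc(S(C)(=O)=O)cn2)[C@H](C)CO1` gives > 200 ug/mL, which is a limit and not a number. The step to compound 3 `CS(=O)(=O)c1ccc(-n2nc(C(F)F)c(C#N)c2NC2CCCC2)cc1` puts cyclopentylamino in place of phenyl on an aromatic carbon. For the measured compounds named here, no measured step covers this change. Resting only on compound 2 and its limit of > 200 ug/mL, with no phenyl at that place, a moderate upward step in this assay is expected, though compound 1 offers no number to measure it from. In this assay the expected value for compound 3 is 45 ug/mL, estimated to lie between 10 ug/mL and 170 ug/mL.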

Compound 3, solubility: 100 ug/mL
Beside the measured number, compound 3's estimate is 2.2-fold (0.35 log units) below it, within the range that was stated.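

No step can be read in this assay: compound 1 has no number there, so compound 3 has no partner to be set against. Still open, on these data alone, is how solubility shifts when cyclopentylamino replaces phenyl on the shared core.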